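Acetyl to dimethylamino on the shared core of compound 1

The source may hold more compounds than are shown below. What is called first, only, known or untested is meant among the compounds shown, and "the series" means these compounds.

Compound 1 `COc1cc(C)cc(-c2c(-c3ccnc(-c4ccc(C(C)=O)cc4)c3)cnn2CC#N)c1` gives 6% in a functional assay on HT-29 cells (Homo sapiens) for cytotoxicity, read by sulforhodamine B assay, with a stated time of 48 h, tested at 10 uM (a lower number here means a stronger effect, a higher number a weaker effect of the compound at the concentration tested), the highest of the three numbers measured. Among the compounds with values here, compound 2 `COc1cc(C)cc(-c2nn(CC#N)cc2-c2ccnc(-c3ccc(N(C)C)cc3)c2)c1` gives -66% and compound 3 `Cc1cc(O)cc(-c2nn(CC#N)cc2-c2ccnc(-c3ccc(N(C)C)cc3)c2)c1` gives -52%; the only step measured between them, a number 14 percentage points higher from compound 2 to compound 3 (beyond the scatter), concerns the oxygen substituent and does not bear on the change considered here. Compound 4 `COc1cc(C)cc(-c2c(-c3ccnc(-c4ccc(N(C)C)cc4)c3)cnn2CC#N)c1` differs from compound 1 by dimethylamino in place of acetyl on an aromatic carbon. Within the data shown here, no measured step covers this exchange directly; what is known is that compound 2 and compound 3, which both carry dimethylamino at this place, lie far below compound 1. The step of a number 41 percentage points lower from compound 1 to compound 4 (beyond the scatter) is therefore expected to be a substantial drop, well beyond the scatter. Compound 4 is estimated at -35%, with a range from -70% to 5%.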

Compound 4, a percentage reported as activity, at one concentration (the size of the read-out at that concentration, not a potency): -48%
Estimate against measurement, compound 4: 13 percentage points above, within the range that was stated.
By their numbers in this assay, from the lowest: compound 2; then compounds 3 and 4 (each within the scatter of the next); then compound 1.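

Working from 4-acetylphenyl to 4-(dimethylamino)phenyl on an otherwise unchanged core gives the first direct reading of this exchange: in this assay, the step is a number 54 percentage points lower from compound 1 to compound 4 (beyond the scatter). This position on the aromatic ring therefore strongly affects the read-out, even though the group swap keeps the same count of heavy atoms. Nothing available explains the size of this step.

On these data alone, whether the step reflects the loss of acetyl or the arrival of dimethylamino remains open. A primary amine or a carboxylic acid at this place could help separate the two.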